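From 3,4-dimethylphenyl back to phenyl

The source may hold more compounds than are shown below. What is called first, only, known or untested is meant among the compounds shown, and "the series" means these compounds.

Measured so far in a functional assay on HT-29 cells (Homo sapiens) for antiproliferative activity, read by sulforhodamine B assay, with a stated time of 48 h; a lower number here means a stronger inhibitor, a higher number a weaker inhibitor:
- Compound 1 `Cc1ccc(NS(=O)(=O)c2ccc(N3CCNC3=O)cc2)cc1`: 480 nM
- Compound 2 `Cc1ccc(NS(=O)(=O)c2ccc(N3CCNC3=O)cc2)cc1C`: 230 nM

Of these two, compound 2 has the lower number and is therefore the stronger inhibitor in this assay. Within the data shown here, its only neighbour, compound 1, gives 480 nM, and that gap lies beyond the usual scatter.

The next compound to be measured is compound 3 `O=C1NCCN1c1ccc(S(=O)(=O)Nc2ccccc2)cc1`. It differs from compound 2 by having phenyl in place of 3,4-dimethylphenyl on a sulfonamide nitrogen.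

Among the measured compounds shown here, only one measured step bears on this change: a 2.1-fold lower number from compound 1 to compound 2 (0.32 log units; beyond the scatter). That modest step came with methyl in place of hydrogen on an aromatic carbon. Compound 3 has no methyl on this ring, so the change runs opposite to that step and goes further. For the measured compounds named here, one step is thin evidence, and no measured compound shows what losing the remaining methyl does. A higher number is still the expectation, by more than that single step. The expected change is a 3.7-fold higher number from compound 2 to compound 3 (0.57 log units; beyond the scatter). For compound 3 the estimated value is 850 nM, with an expected range of 330 nM to 2200 nM.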

Compound 3, half-maximal inhibitory concentration: 280 nM
Beside the measured number, compound 3's estimate is 3.0-fold (0.48 log units) above it; the measured number lies below the stated range.
By their numbers in this assay, from the lowest: compounds 2, 3 and 1 (each within the scatter of the next, the first and the last beyond it).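

On the sulfonamide nitrogen, phenyl in place of 3,4-dimethylphenyl gives, in this assay, a 1.2-fold higher number from compound 2 to compound 3 (0.09 log units; within the scatter), so removing both methyl groups together produces no change that can be told from assay noise. Hydrogen in place of the single methyl gives a 1.7-fold lower number from compound 1 to compound 3 (0.23 log units; within the scatter), so the ring with no methyl also cannot be separated from the ring with one. The three compounds therefore form no steady ladder with methyl count: only the gap between the rings with one and two methyl groups lies beyond the scatter, and the earlier step alone could not show this. No measurement here accounts for this result.

What remains open is whether any group on this ring can move the number well beyond the scatter, since methyl is the only group shown there. A chlorine, a methoxy group, an amine or a carboxylic acid on the ring, or an ethyl group in place of methyl, would each put that question to the test.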